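Swapping a Methylphenyl for Pyridyl on a Triazole

The compounds below may be only part of what the source reports. "The series", "measured", "known", "first", "only" and "open" are said of these compounds alone.

Compound 3 `C=C1C(=O)[C@]23C[C@@]1(O)CC[C@H]2c1ccc(OS(=O)(=O)c2ccc(C)cc2)c(C)c1[C@@H]3Cn1cc(-c2ccc(C)cc2)nn1` holds the highest of the two numbers measured in a functional assay on SMMC-7721 cells (Homo sapiens) for cytotoxicity, read by MTT assay, with a stated time of 4 days; on this read-out higher numbers stand for weaker inhibition and lower numbers for stronger inhibition: compound 3 gives 4410 nM. Compound 2 `C=C1C(=O)[C@]23C[C@@]1(O)CC[C@H]2c1ccc(O)c(C)c1[C@@H]3Cn1cc(-c2ccc(C)cc2)nn1` gives 920 nM, and the step of a 4.8-fold higher number from compound 2 to compound 3 (0.68 log units; beyond the scatter) is modest. Compound 1 `C=C1C[C@]23C[C@@]1(O)CC[C@H]2c1ccc(O)c(C)c1[C@@H]3Cn1cc(-c2ccc(C)cc2)nn1` is reported only as a limit in this assay, namely > 20000 nM. Compound 4 `C=C1C(=O)[C@]23C[C@@]1(O)CC[C@H]2c1ccc(OS(=O)(=O)c2ccc(C)cc2)c(C)c1[C@@H]3Cn1cc(-c2ccccn2)nn1` is not yet measured; its change from compound 3 is pyridin-2-yl in place of 4-methylphenyl on an aromatic carbon. Within the data shown here, no measured step touches the group on the triazole, since the single measured step concerns a different part of the shared core. The expectation for compound 4 therefore rests on compound 3 alone, with the step of a 1.0-fold higher number from compound 3 to compound 4 (0.01 log units; within the scatter) expected to remain within the scatter. Compound 4 is estimated at 4500 nM, between 1500 nM and 14000 nM.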

Compound 4, half-maximal inhibitory concentration: 2830 nM
Beside the measured number, compound 4's estimate is 1.6-fold (0.20 log units) above it; the range from low to high includes it.
By their numbers in this assay, from the lowest: compound 2; then compounds 4 and 3 (each within the scatter of the next). At a limit, above all of these: compound 1.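

Among these compounds, the group on the triazole changes here for the first time, and in this assay the exchange gives a 1.6-fold lower number from compound 3 to compound 4 (0.19 log units; within the scatter) as its step. On this aromatic carbon, then, pyridin-2-yl, with its ring nitrogen, can replace 4-methylphenyl without a step beyond the scatter, in compounds carrying the (4-methylphenyl)sulfonyl group on the oxygen. No available evidence bears on why this result arises.

As far as these compounds go, what an amine or a carboxylic acid would do on this carbon stays open. So does whether pyridin-2-yl would behave alike with the hydrogen on the oxygen, as in compound 2.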